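This account rests on a few compounds, and the source may have more. Where it says the series, first, only, none or still open, it means among the compounds named here.

Compound 3 `COc1ccc(C(=O)/C=C/c2cc(-c3cc(OC)c(OC)c(OC)c3)n[nH]2)cc1` gives -57% in a functional assay on A498 cells (Homo sapiens) for cytotoxicity, read by sulforhodamine B assay, with a stated time of 48 h, tested at 10 uM; on this read-out lower numbers stand for a stronger effect and higher numbers for a weaker effect at the one concentration tested. Among the three measured compounds it stands second highest: compound 2 `COc1ccc(C(=O)/C=C/c2cc(-c3cc(OC)c(OC)c(OC)c3)n[nH]2)cc1OC` gives -87%, and the step of a number 30 percentage points higher from compound 2 to compound 3 (beyond the scatter) is modest, whereas compound 1 `COc1cc(-c2cc(/C=C/C(=O)c3ccc(Cl)c(Cl)c3)[nH]n2)cc(OC)c1OC` gives 43%, and the step of a number 100 percentage points lower from compound 1 to compound 3 (beyond the scatter) is large. Compound 4 `COc1cc(-c2cc(/C=C/C(=O)c3ccc(F)c(F)c3)[nH]n2)cc(OC)c1OC` differs from compound 3 by 3,4-difluorophenyl in place of 4-methoxyphenyl on a carbonyl carbon. Within the data shown here, the steps that bear on this change are those in which 3,4-dichlorophenyl gave way to a methoxy-bearing ring: a number 130 percentage points lower from compound 1 to compound 2 (beyond the scatter) and a number 100 percentage points lower from compound 1 to compound 3 (beyond the scatter). Among the measured compounds shown here, compound 4 carries a ring closer in kind to that of compound 1, so a large upward step is expected, a number 77 percentage points higher from compound 3 to compound 4 (beyond the scatter), although no fluorine-bearing compound has been measured. Compound 4 is expected to give 20%, within -40% to 60%.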

Compound 4, a percentage reported as activity, at one concentration (the size of the read-out at that concentration, not a potency): -14%
The estimate for compound 4 lay 34 percentage points above the measured number; low and high end bracket the measured number.
By their numbers in this assay, from the lowest: compound 2; then compound 3; then compound 4; then compound 1.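

Two halogen-bearing rings on this carbonyl carbon are not interchangeable: 3,4-difluorophenyl in place of 3,4-dichlorophenyl gives a number 57 percentage points lower from compound 1 to compound 4 (beyond the scatter), a stronger effect in this assay. Yet 3,4-difluorophenyl still falls short of both methoxy-bearing rings, with a number 43 percentage points higher from compound 3 to compound 4 (beyond the scatter) and a number 73 percentage points higher from compound 2 to compound 4 (beyond the scatter), so among these four compounds both halogen-bearing rings give weaker effects than both methoxy-bearing rings. No measurement here explains these differences. As far as these compounds go, it remains open how a plain phenyl ring or a ring bearing a single fluorine would fall within this order. From the compounds shown here alone, a ring carrying an amine or a carboxylic acid on this carbonyl carbon also remains untested here.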